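Pyridin-3-yl to pyridin-4-yl on compound 1

This account rests on a few compounds, and the source may have more. Where it says the series, first, only, none or still open, it means among the compounds named here.

Among the compounds with values here, in a functional assay on HepG2 cells (Homo sapiens) for antiproliferative activity, read by colorimetric assay and MTT assay, with a stated time of 48 h (a lower number here means a stronger inhibitor, a higher number a weaker inhibitor), compound 1 (`Cc1ccc(S(=O)(=O)NC(=O)c2cccnc2)cc1`) gives 12300 nM, the higher of the two numbers so far. Compound 2 (`O=C(NS(=O)(=O)c1ccc(Cl)cc1)c1cncc(C(=O)NS(=O)(=O)c2ccc(Cl)cc2)c1`) gives 5400 nM, a lower number by a margin beyond the usual scatter. These two compounds differ in more than one place, so the pair does not isolate any single change.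

Compound 3 (`Cc1ccc(S(=O)(=O)NC(=O)c2ccncc2)cc1`) has not yet been measured. Its difference from compound 1 is pyridin-4-yl in place of pyridin-3-yl on a carbonyl carbon. Within the data shown here, no measured pair shows the size of such a change. A small step within the scatter, with no favoured direction, is therefore expected in this assay. The expected step is a 1.1-fold lower number from compound 1 to compound 3 (0.05 log units; within the scatter). The estimate for compound 3 is 11000 nM, with an expected range of 4000 nM to 30000 nM.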

Compound 3, half-maximal inhibitory concentration: 20200 nM
Beside the measured number, compound 3's estimate is 1.8-fold (0.26 log units) below it; measured number inside the range.
By their numbers in this assay, from the lowest: compound 2; then compounds 1 and 3 (each within the scatter of the next).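

Within the data shown here, the first comparison that isolates a single change, pyridin-4-yl in place of pyridin-3-yl on a carbonyl carbon, gives a 1.6-fold higher number from compound 1 to compound 3 (0.22 log units; within the scatter) in this assay. Among these compounds, at this place, then, the two groups cannot be told apart on these numbers, and the shift of the ring nitrogen alone gives no step that can be read as a real difference. Nothing at hand bears on the reason for this result.

From the compounds shown here alone, whether phenyl or pyridin-2-yl on the same carbonyl carbon would give a step beyond the scatter remains open, as does the outcome of an amine or a carboxylic acid on that ring. Compound 2 still differs from compound 1 and compound 3 in more than one place, so no single feature can be linked to its number.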